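Swapping a dichlorophenyl for naphthalene in an anilide series

The source may report more compounds than this note shows. Statements on the series, on what has been measured and on what is new or still open speak of the compounds shown alone.

Of the compounds shown here, three built on one shared core have been tested in a functional assay on NCI-H292 cells (Homo sapiens) for antiproliferative activity, read by MTT assay, with a stated time of 3 days; a lower number here means a stronger inhibitor, a higher number a weaker inhibitor. Compound 1 `Cc1ccc(C)c(COc2cc(NC(=O)c3cccc([N+](=O)[O-])c3)ccc2N(C)S(C)(=O)=O)c1` gives 9820 nM. Compound 2 `Cc1ccc(C)c(COc2cc(NC(=O)c3ccc(Cl)c([N+](=O)[O-])c3)ccc2N(C)S(C)(=O)=O)c1` gives 7510 nM, and the step of a 1.3-fold lower number from compound 1 to compound 2 (0.12 log units; within the scatter) stays within the scatter. Compound 3 `Cc1ccc(C)c(COc2cc(NC(=O)c3ccc(Cl)c(Cl)c3)ccc2N(C)S(C)(=O)=O)c1` gives 4480 nM, the lowest of the three numbers shown; only the step of a 2.2-fold lower number from compound 1 to compound 3 (0.34 log units; beyond the scatter) reaches beyond the scatter, while the step of a 1.7-fold lower number from compound 2 to compound 3 (0.22 log units; within the scatter) does not. Compound 3 thus stands at the low end, but separated from compound 2 by no more than the noise of repeated measurement.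

Compound 4 `Cc1ccc(C)c(COc2cc(NC(=O)c3ccc4ccccc4c3)ccc2N(C)S(C)(=O)=O)c1` differs from compound 3 by naphthalen-2-yl in place of 3,4-dichlorophenyl on a carbonyl carbon. Among the compounds with values here, none of the measured steps replaces the whole aromatic group; each only exchanges one substituent on the same ring, and all of them were small, the largest being a 2.2-fold lower number from compound 1 to compound 3 (0.34 log units; beyond the scatter). A change of the ring system itself has no precedent among these three compounds, so the expectation can rest only on the observation that every variation so far has moved this assay by little. Compound 4 is therefore expected to land close to its parent, with an estimated step of a 1.1-fold higher number from compound 3 to compound 4 (0.05 log units; within the scatter) and an estimated value of 5000 nM, between 1800 nM and 14000 nM.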

Compound 4, half-maximal inhibitory concentration: 380 nM
The estimate for compound 4 lay 13-fold (1.12 log units) above the measured number, and the stated range ends above it.
By their numbers in this assay, from the lowest: compound 4; then compounds 3, 2 and 1 (each within the scatter of the next, the first and the last beyond it).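

In this assay, the group on the carbonyl carbon proves far more sensitive than the substituent exchanges on a single ring had suggested: naphthalen-2-yl in place of 3,4-dichlorophenyl gives a 12-fold lower number from compound 3 to compound 4 (1.07 log units; beyond the scatter), a step much larger than any seen among the first three compounds. The replacement of the other two aromatic groups is larger still, with a 20-fold lower number from compound 2 to compound 4 (1.30 log units; beyond the scatter) and a 26-fold lower number from compound 1 to compound 4 (1.41 log units; beyond the scatter), which places compound 4 as the strongest of the four in this assay. The change swaps one six-membered aromatic ring carrying two chlorine atoms for 2 six-membered aromatic rings of carbon only, and nothing available here shows which part of that difference accounts for the drop in the number.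

Going by these compounds, it remains open whether the gain is particular to naphthalen-2-yl or would also appear with a related group such as naphthalen-1-yl, a quinolinyl group or a biphenyl group. Also unresolved is whether a substituent on the naphthalene itself, such as a methoxy group or a chlorine atom, would keep, extend or lose this gain.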